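The compounds below may be only part of what the source reports. "The series", "measured", "known", "first", "only" and "open" are said of these compounds alone.

Measured compounds:
- compound 2 `COC(=O)c1cc(-c2cccc(NC(=O)c3ccc(/C=C/C(=O)c4ccc(C)c(F)c4)cc3)c2)on1`: > 50 ug/mL
- compound 3 `COC(=O)c1cc(-c2cccc(NC(=O)c3ccc(/C=C/C(=O)c4cccc(Br)c4)cc3)c2)on1`: > 100 ug/mL
- compound 1 `COC(=O)c1cc(-c2cccc(NC(=O)c3ccc(/C=C/C(=O)c4cccnc4)cc3)c2)on1`: "not determined" (no result reported)

All three share one core and differ only in the aromatic ring that sits on a carbonyl carbon. In an ADME assay on Vero cells (Chlorocebus sabaeus) for cytotoxicity, read by MTT assay, with a stated time of 72 h (on this read-out higher numbers stand for lower toxicity in this test and lower numbers for higher toxicity in this test), compound 2 gives > 50 ug/mL, which is a limit of the assay and not a number. Compound 3 gives > 100 ug/mL in this assay, again a limit. For compound 1 this assay reports "not determined" (no result reported). Among the compounds with values here, the single step between measured compounds, a step that the two limits leave unreadable from compound 2 to compound 3, is consequently of unknown size, since both ends rest on the limits the limit of > 50 ug/mL in this assay, at which 1 of the 3 values shown sits, and (the limit of > 100 ug/mL in this assay, at which 1 of the 3 values shown sits).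

Compound 4 `CCCOc1ccc(C(=O)/C=C/c2ccc(C(=O)Nc3cccc(-c4cc(C(=O)OC)no4)c3)cc2)cc1` arises from compound 2 through the change (4-propoxyphenyl in place of 3-fluoro-4-methylphenyl on a carbonyl carbon). Within the data shown here, no measured step resolves what such a change in this ring does to the read-out, so no shift beyond the scatter is expected in either direction. Compound 4 is expected to sit near the same limit, with an expected step that the limit leaves unreadable from compound 2 to compound 4. The estimate for compound 4 is 80 ug/mL, ranging from 40 ug/mL to 200 ug/mL.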

Compound 4, half-maximal cytotoxic concentration: > 40 ug/mL
Compound 4 was reported as a limit; the forecaster's own chance of this, stated with the estimate: 80%; the middle value does not contradict the limit.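

No step can be read between compound 2, compound 3 and compound 4: each of the three results is a limit of the assay and not a number. Left open is whether changing the aromatic ring on the carbonyl carbon shifts the half-maximal cytotoxic concentration at all, and by how much.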